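Removing All Methoxy Groups and the Paw Edema Inhibition Number

The compounds below may be only part of what the source reports. "The series", "measured", "known", "first", "only" and "open" are said of these compounds alone.

Measured compounds:
compound 1, `COc1ccc(-c2nnc(SCC(=O)Nc3ccc(C(C)=O)cc3)n2-c2ccccc2)cc1`: 60%
compound 2, `COc1cc(-c2nnc(SCC(=O)Nc3ccc(C(C)=O)cc3)n2-c2ccccc2)cc(OC)c1OC`: 63%

In a functional assay on the whole organism (strain albino) for inhibition, with Rattus norvegicus as the target, read by paw edema, with stated times of 30 min and 5 h, at a dose of 0.28 mmol/kg by the oral route (a lower number here means less inhibition, a higher number more inhibition at the dose given (going by the name of the read-out)), compound 1 gives 60% and compound 2 gives 63%. Within the data shown here, compound 2 holds the highest of the two numbers, but its only neighbour, compound 1, lies within the usual scatter, so the two cannot be ranked. Among the measured compounds shown here, the single measured step, a number 3 percentage points higher from compound 1 to compound 2 (within the scatter), shows that adding two methoxy groups to the aromatic ring on that carbon left the read-out essentially unchanged.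

Compound 3, `CC(=O)c1ccc(NC(=O)CSc2nnc(-c3ccccc3)n2-c2ccccc2)cc1`, is not yet measured. The change is phenyl in place of 3,4,5-trimethoxyphenyl on an aromatic carbon. For the measured compounds named here, this is the only step that bears on the new compound, and since it was small, stripping all three methoxy groups is expected to give at most a modest shift, a number 8 percentage points lower from compound 2 to compound 3 (within the scatter), with a slight downward lean because compound 1 already gives 60% with one methoxy group removed. Compound 3 is therefore expected to show about 55%, within a range from 40% to 68%.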

Compound 3, a percentage reported as inhibition, in the whole organism at one dose (the size of the read-out at that dose, not a potency): 63%
Beside the measured number, compound 3's estimate is 8 percentage points below it; the range from low to high includes it.
By their numbers in this assay, from the lowest: compounds 1, 2 and 3 (each within the scatter of the next).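

Among these compounds, with the methoxy groups gone entirely, the read-out does not respond: in this assay, phenyl in place of 3,4,5-trimethoxyphenyl gives no change at the digits printed from compound 2 to compound 3 (within the scatter), and hydrogen in place of the single methoxy gives a number 3 percentage points higher from compound 1 to compound 3 (within the scatter). Until now every measured compound carried at least one methoxy group, whereas these steps show that, on this aromatic carbon of the five-membered ring, a plain phenyl group reaches the same level within the scatter, so compounds 1, 2 and 3 cannot be told apart. No available information explains this flat result.

On these data alone, it remains open whether an amine or a carboxylic acid on this phenyl ring, or a longer alkyl chain in its place, would move the number. A single dose also leaves open whether these three compounds would separate at other doses.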